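This account rests on a few compounds, and the source may have more. Where it says the series, first, only, none or still open, it means among the compounds named here.

In a functional assay on DU-145 cells (Homo sapiens) for inhibition, read by MTT assay, with a stated time of 72 h (a higher number here means a weaker inhibitor, a lower number a stronger inhibitor), compound 1 `O=C1C=C(N2CCN(c3ccc(F)cc3)CC2)C(=O)c2ccccc21` gives 11700 nM. Compound 2 `O=C1C=C(N2CCN(c3ccc(Br)cc3)CC2)C(=O)c2ccccc21` is reported in this assay only as a limit of the assay, > 50000 nM. The step is an at least 4.2-fold higher number from compound 1 to compound 2 (0.63 log units; beyond the scatter), so compound 2 stands at the limit of > 50000 nM in this assay, at which 1 of the 2 values shown sits, with no exact number known. Compound 3 `Cc1ccccc1N1CCN(C2=CC(=O)c3ccccc3C2=O)CC1` differs from compound 2 by 2-methylphenyl in place of 4-bromophenyl on an amine nitrogen in a ring. Going by the values given here, the single measured step concerns a halogen swap and bears only loosely on this change, so the direction is uncertain and a smaller number is expected, though it may still sit near the limit. Compound 3 is estimated at 25000 nM, between 6000 nM and 60000 nM, an expected at least 2.0-fold lower number from compound 2 to compound 3 (0.30 log units; that floor lies within the scatter).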

Compound 3, half-maximal inhibitory concentration: 5700 nM
For compound 3 the middle estimate is 4.4-fold (0.64 log units) above the measured one, and the stated range ends above it.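

A phenyl group without a halogen is tolerated on this amine nitrogen in a ring: 2-methylphenyl gives an at least 8.7-fold lower number from compound 2 to compound 3 (0.94 log units; beyond the scatter). That step starts from a limit of the assay, not a number, so its true size stays unknown: the limit of > 50000 nM in this assay, at which 1 of the 3 values shown sits.

Against 4-fluorophenyl the change gives a 2.1-fold lower number from compound 1 to compound 3 (0.31 log units; beyond the scatter), which makes compound 3 the strongest of the three in this assay. Here the group's identity and its place on the phenyl ring change together, so the compounds shown cannot separate the two. As far as these compounds go, whether a methoxy group or an amine on that phenyl ring would lower the number further stays open.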